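The source may hold more compounds than are shown below. What is called first, only, known or untested is meant among the compounds shown, and "the series" means these compounds.

All three measured compounds share one core and differ only in the aromatic ring attached to the amide nitrogen. Compound 1 `O=C(CCC(=O)OCCCCCCSc1ccc([N+](=O)[O-])c2nonc12)Nc1ccccc1` carries a plain phenyl ring there; in an assay on isolated protein for inhibition of glutathione S-transferase Mu 2 (Homo sapiens), with a stated time of 10 min (on this read-out higher numbers stand for weaker inhibition and lower numbers for stronger inhibition), compound 1 gives 700 nM. Compound 2 `O=C(CCC(=O)OCCCCCCSc1ccc([N+](=O)[O-])c2nonc12)Nc1ccccc1Cl` carries a chloro on an aromatic carbon of that ring, and in this assay compound 2 gives 330 nM, which is a 2.1-fold lower number from compound 1 to compound 2 (0.33 log units; beyond the scatter). Compound 3 `O=C(CCC(=O)OCCCCCCSc1ccc([N+](=O)[O-])c2nonc12)Nc1cccc(Cl)c1` carries its chloro on a different aromatic carbon, and in this assay compound 3 gives 1100 nM. Compound 3 thus has the highest of the three numbers: the step is a 1.6-fold higher number from compound 1 to compound 3 (0.20 log units; within the scatter), while the step is a 3.3-fold higher number from compound 2 to compound 3 (0.52 log units; beyond the scatter).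

Compound 4 `O=C(CCC(=O)OCCCCCCSc1ccc([N+](=O)[O-])c2nonc12)Nc1ccc(F)cc1` introduces a new variation: 4-fluorophenyl in place of 3-chlorophenyl on an amide-type nitrogen. Of the measured steps, two bear on it. The step of a 1.6-fold higher number from compound 1 to compound 3 (0.20 log units; within the scatter) shows that a chloro on that ring can leave the number essentially unchanged, and the step of a 3.3-fold higher number from compound 2 to compound 3 (0.52 log units; beyond the scatter) shows that moving the substituent can shift the number modestly. Among the compounds with values here, no measured compound carries a fluoro, so the effect of this exact change is not covered by the data. The expectation is therefore that compound 4 sits near compound 1 and compound 3, with a step of a 1.5-fold lower number from compound 3 to compound 4 (0.17 log units; within the scatter) in this assay. Compound 4 is estimated at 750 nM, within a range from 350 nM to 1600 nM.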

Compound 4, half-maximal inhibitory concentration: 320 nM
Compound 4: the middle estimate sits 2.3-fold (0.37 log units) above what was measured, outside the stated range (below it).
By their numbers in this assay, from the lowest: compounds 4 and 2 (each within the scatter of the next); then compounds 1 and 3 (each within the scatter of the next).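

Replacing a hydrogen on an aromatic carbon with fluoro gives a step beyond the scatter in this assay (a 2.2-fold lower number from compound 1 to compound 4 (0.34 log units; beyond the scatter)), so a halogen other than chloro can also move the number at this amide-type nitrogen. Exchanging 3-chlorophenyl for 4-fluorophenyl gives a similar modest step (a 3.4-fold lower number from compound 3 to compound 4 (0.54 log units; beyond the scatter)), whereas the comparison with the other chloro ring shows no real difference (a 1.0-fold lower number from compound 2 to compound 4 (0.01 log units; within the scatter)), so a halogen on this ring can match that chloro ring or fall short of it, depending on the compound, and compound 3 goes against any rule that a halogen here lowers the number. Nothing in the available data explains why these rings differ.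

Going by these compounds, whether the level of compound 4 belongs to the fluoro itself or to where it sits on the ring stays open, and a 4-chlorophenyl group on the same nitrogen would help separate the two. A 4-methoxyphenyl or 4-aminophenyl group would show whether something other than a halogen can take this place on the ring.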